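This account rests on a few compounds, and the source may have more. Where it says the series, first, only, none or still open, it means among the compounds named here.

Compound 1 `Cc1ccc(NC(=O)C(C)NS(=O)(=O)c2cccc3cccnc23)c(C)c1`: > 50000 nM (a limit)
Compound 2 `CCc1ccccc1NC(=O)[C@@H]1CCCN1S(=O)(=O)c1cccc2cccnc12`: > 50000 nM (a limit)

In an ADME assay on HEp-2 cells (Homo sapiens) for cytotoxicity (a higher number here means that more compound is tolerated, a lower number that less compound is tolerated), compound 2 gives > 50000 nM, which is a limit of the assay and not a number. Compound 1 also gives only a limit, so the record so far comes to the limit of > 50000 nM in this assay, at which 2 of the 2 values shown sit. Compound 3 `O=C(Nc1ccc(Cl)cc1Cl)[C@@H]1CCCN1S(=O)(=O)c1cccc2cccnc12` departs from compound 2 in one place: 2,4-dichlorophenyl in place of 2-ethylphenyl on an amide-type nitrogen. In words, 2,4-dichlorophenyl stands in place of 2-ethylphenyl on an amide-type nitrogen. Going by the values given here, no pair of measured compounds shows what such an exchange does, so the expectation rests only on the limit reached by compound 2. A small downward move, or none beyond the scatter, is expected, and the estimated step is an at least 1.1-fold lower number from compound 2 to compound 3 (0.04 log units; that floor lies within the scatter). In this assay the estimate for compound 3 is 45000 nM, with an expected range of 18000 nM to 50000 nM.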

Compound 3, half-maximal cytotoxic concentration: > 50000 nM
Compound 3: a limit, no number (the forecaster's own chance of this, stated with the estimate: 65%); middle value at least 1.1-fold (0.04 log units) away from the limit.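

In this assay compound 3 gives > 50000 nM, which is a limit of the assay and not a number. Going by these compounds alone, compound 2 also gives only a limit, so no step to compound 3 can be read. The compounds shown leave open what 2,4-dichlorophenyl in place of 2-ethylphenyl does to the half-maximal cytotoxic concentration.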